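The compounds below may be only part of what the source reports. "The series", "measured", "known", "first", "only" and "open" are said of these compounds alone.

In a functional assay on SW480 cells (Homo sapiens) for antiproliferative activity, read by MTT assay, with a stated time of 48 h (on this read-out lower numbers stand for stronger inhibition and higher numbers for weaker inhibition), compound 1 (`CCCCCCC(CCO)n1cnc2c(N)ncnc21`) gives > 50000 nM as a limit of the assay, not a number. Compound 2 (`CCCCCCCC(CCO)n1cnc2c(N)ncnc21`) gives > 50000 nM as a limit too. Compound 2 therefore stands at the limit of > 50000 nM in this assay, at which 2 of the 2 values shown sit, without a number. Compound 3 (`CCCCCCCCC(CCO)n1cnc2c(N)ncnc21`) differs from it by methyl in place of hydrogen on a saturated chain carbon, eight bonds along the chain from an aromatic nitrogen. Among the measured compounds shown here, the one like change measured is a step that the two limits leave unreadable from compound 1 to compound 2 and it sets no size, so no shift beyond the scatter is foreseen. The step expected in this assay is a number no higher from compound 2 to compound 3 (the limit leaves the size open) with neither direction favoured. For compound 3 the estimated value is 50000 nM (range 20000 nM to 100000 nM) and another limit is the likeliest report.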

Compound 3, half-maximal inhibitory concentration: 20700 nM
Compound 3: the middle estimate sits 2.4-fold (0.38 log units) above what was measured, and the stated range covers the measured number.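

In this assay, among the compounds shown here, methyl in place of hydrogen on a saturated chain carbon, eight bonds along the chain from an aromatic nitrogen, gives the first step that can be read in one direction: an at least 2.4-fold lower number from compound 2 to compound 3 (0.38 log units; beyond the scatter). Ethyl in place of hydrogen at the carbon seven bonds along the chain gives an at least 2.4-fold lower number from compound 1 to compound 3 (0.38 log units; beyond the scatter). Compound 1 and compound 2 remain at a limit of the assay, and the step between them cannot be read: the limit of > 50000 nM in this assay, at which 2 of the 3 values shown sit.

Going by these compounds, the true size of both steps stays open, since each starts from a limit. On these data alone, whether a longer chain would lower the number further, or whether an amine or a carboxylic acid in place of the terminal hydroxyl would keep it, also stays open.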